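Trading 4-cyanophenyl for 3-methoxyphenyl on a shared core

The compounds below may be only part of what the source reports. "The series", "measured", "known", "first", "only" and "open" are said of these compounds alone.

In a functional assay on BGC-823 cells (Homo sapiens) for antiproliferative activity, read by MTT assay, with a stated time of 48 h (on this read-out higher numbers stand for weaker inhibition and lower numbers for stronger inhibition), compound 3 (`CCn1cc(-c2ccc(C#N)cc2)c(=O)c2cc(F)c(N3CCNCC3)cc21`) gives 18700 nM and sits within the scatter of compound 2 (`CCn1cc(-c2ccc(Cl)cc2)c(=O)c2cc(F)c(N3CCNCC3)cc21`) at 14600 nM while compound 1 (`CCn1cc(-c2ccccc2)c(=O)c2cc(F)c(N3CCNCC3)cc21`) lies apart at 75400 nM on the same scale. Chloro in place of hydrogen on an aromatic carbon gave a 5.2-fold lower number from compound 1 to compound 2 (0.71 log units; beyond the scatter) and cyano in the same role gave a 4.0-fold lower number from compound 1 to compound 3 (0.61 log units; beyond the scatter) while cyano in place of chloro gave a 1.3-fold higher number from compound 2 to compound 3 (0.11 log units; within the scatter) only.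

The next compound, compound 4 (`CCn1cc(-c2cccc(OC)c2)c(=O)c2cc(F)c(N3CCNCC3)cc21`), has 3-methoxyphenyl in place of 4-cyanophenyl on an aromatic carbon. Among the measured compounds shown here, none of the measured compounds carries methoxy, so these steps bear on the change only indirectly. For the measured compounds named here, both substituted compounds measured so far gave lower numbers than compound 1, and the two steps from it are of similar size. Compound 4 is therefore expected to keep much of that gain, though with an untested group a small move towards a higher number seems more likely than a further drop. The expected move is a 1.5-fold higher number from compound 3 to compound 4 (0.18 log units; within the scatter) in this assay on this estimate. Compound 4 is estimated at 28000 nM (expected range 11000 nM to 70000 nM).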

Compound 4, half-maximal inhibitory concentration: 14700 nM
Compound 4: the middle estimate sits 1.9-fold (0.28 log units) above what was measured; the range from low to high includes it.
By their numbers in this assay, from the lowest: compounds 2, 4 and 3 (each within the scatter of the next); then compound 1.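

In this assay, methoxy in place of hydrogen gives a 5.1-fold lower number from compound 1 to compound 4 (0.71 log units; beyond the scatter), so a third group, and the first one placed as a 3-substituent on the phenyl, joins chloro and cyano beyond the scatter from the unsubstituted compound. Taking 3-methoxyphenyl in place of 4-cyanophenyl gives a 1.3-fold lower number from compound 3 to compound 4 (0.10 log units; within the scatter), and taking it in place of 4-chlorophenyl gives a 1.0-fold higher number from compound 2 to compound 4 (0.00 log units; within the scatter), so this assay does not tell these three groups apart at this aromatic carbon of the shared core. No measurement beyond these antiproliferative values is available to account for what the three groups have in common.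

Compound 4 differs from compound 2 and compound 3 both in the group and in where it sits on the phenyl, so the compounds shown cannot separate the two, and a 4-methoxyphenyl or a 3-chlorophenyl group would be needed to do so. They also leave open whether an amine or a carboxylic acid on that phenyl would stay level with compound 2, compound 3 and compound 4 or return towards compound 1.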